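Aryl variation at the five-membered ring of a nucleoside core

A few compounds are considered here, and "the series" means these few. Any claim that something is new, unique, unknown or untested is made for them only; others in the source may bear on it.

Measured so far in a functional assay on HeLa S3 cells (Homo sapiens) for antiproliferative activity, read by XTT assay, with a stated time of 72 h; a higher number here means a weaker inhibitor, a lower number a stronger inhibitor:
compound 1 `O=c1[nH]cnc2c1c(-c1ccsc1)cn2[C@@H]1O[C@H](CO)[C@@H](O)[C@H]1O`: > 20000 nM
compound 2 `O=c1[nH]cnc2c1c(-c1ccco1)cn2[C@@H]1O[C@H](CO)[C@@H](O)[C@H]1O`: 5780 nM
compound 3 `O=c1[nH]cnc2c1c(-c1cc3ccccc3o1)cn2[C@@H]1O[C@H](CO)[C@@H](O)[C@H]1O`: > 20000 nM

For compound 3 the value in this assay is a limit of the assay, not a number. Compound 1 likewise sits at a limit of this assay. Going by the values given here, the only numeric value is that of compound 2. The step of an at least 3.4-fold higher number from compound 2 to compound 3 (0.53 log units; beyond the scatter) is therefore readable only as a lower bound, and the step that the two limits leave unreadable from compound 1 to compound 3 is not readable at all; two of the three values sit at the same limit (the limit of > 20000 nM in this assay, at which 2 of the 3 values shown sit).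

Compound 4 `O=c1[nH]cnc2c1c(-c1ccccc1)cn2[C@@H]1O[C@H](CO)[C@@H](O)[C@H]1O` is not yet measured. It differs from compound 3 as follows: phenyl in place of 1-benzofuran-2-yl on an aromatic carbon.

What bears on this step is thin. The step of an at least 3.4-fold lower number from compound 1 to compound 2 (0.53 log units; beyond the scatter) shows that among the three aryl groups only furan-2-yl gives a number, while thiophen-3-yl and 1-benzofuran-2-yl both leave the assay at its limit. Phenyl in place of 1-benzofuran-2-yl removes a ring that in compound 3 did not bring the value into the readable range, and the value of compound 3 is itself a limit, so no direction can be read for the step.

Compound 4 is expected to give 15000 nM in this assay, within 4000 nM to 40000 nM. The expected step is an at least 1.3-fold lower number from compound 3 to compound 4 (0.12 log units; that floor lies within the scatter), and a result at the limit is considered likely.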

Compound 4, half-maximal inhibitory concentration: > 20000 nM
Compound 4: no number, only a limit; the forecaster's own chance of this, stated with the estimate: 55%; at least 1.3-fold (0.12 log units) between middle value and limit.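

In this assay compound 4 gives > 20000 nM, which is a limit of the assay and not a number. Phenyl therefore joins thiophen-3-yl and 1-benzofuran-2-yl at the limit, which leaves furan-2-yl in compound 2 as the only one of the four aryl groups at this position with a numeric value, and removing the five-membered ring of 1-benzofuran-2-yl to leave phenyl does not bring the result into the readable range. Replacing furan-2-yl with phenyl gives an at least 3.4-fold higher number from compound 2 to compound 4 (0.53 log units; beyond the scatter), readable only as a lower bound, while the steps to compound 4 from compound 1 and compound 3 cannot be read, and the series now gathers at one value: the limit of > 20000 nM in this assay, at which 3 of the 4 values shown sit.

Open, as far as these compounds go, is whether the numeric value of compound 2 belongs to furan-2-yl itself or would also appear with close relatives such as furan-3-yl or thiophen-2-yl, or with an amine or a carboxylic acid carried on the furan ring. Equally open, from the compounds shown here alone, is whether a non-aromatic group on this carbon, such as a methyl, an amine or a longer alkyl chain, would give a number in this assay at all.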